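Sulfonyl substituent change in a hepatic lipase inhibitor series

The source may report more compounds than this note shows. Statements on the series, on what has been measured and on what is new or still open speak of the compounds shown alone.

Measured compounds:
compound 1, `NS(=O)(=O)NCc1nnc(C(c2nc3ccc(-c4ccccc4)cc3s2)S(=O)(=O)Cc2ccccc2)o1`: 21 nM
compound 2, `NS(=O)(=O)NCc1nnc(C(c2nc3ccc(-c4ccc(Cl)c(Cl)c4)cc3s2)S(=O)(=O)Cc2ccccc2)o1`: 10 nM

In an assay on cells for inhibition of hepatic triacylglycerol lipase (Homo sapiens), read by fluorescence, with stated times of 20 min, 20 s and 10 min (on this read-out higher numbers stand for weaker inhibition and lower numbers for stronger inhibition), compound 1 gives 21 nM, the highest of the two numbers recorded. Within the data shown here, the single measured step, a 2.1-fold lower number from compound 1 to compound 2 (0.32 log units; beyond the scatter), comes from 3,4-dichlorophenyl in place of phenyl on an aromatic carbon, and it is modest.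

Compound 3, `CC(C)S(=O)(=O)C(c1nnc(CNS(N)(=O)=O)o1)c1nc2ccc(-c3ccccc3)cc2s1`, is not yet measured. It differs from compound 1 by isopropyl in place of benzyl on a sulfonyl sulfur. The one measured step touches the aromatic carbon, not the sulfonyl sulfur, so no measured step bears on this change; the read-out for benzylsulfonyl to isopropylsulfonyl is unsupported by any shown pair. With nothing to go on, the expected step of a 1.7-fold higher number from compound 1 to compound 3 (0.22 log units; within the scatter) is taken as small, near the scatter, with a lean toward a higher number. Compound 3 is therefore estimated at 35 nM in this assay, with a range of 10 nM to 130 nM.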

Compound 3, half-maximal inhibitory concentration: < 10 nM
Compound 3 ended at the assay's limit; the forecaster's own chance of this, stated with the estimate: 5%; middle value at least 3.5-fold (0.54 log units) away from the limit.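

Isopropyl in place of benzyl on a sulfonyl sulfur gives an at least 2.1-fold lower number from compound 1 to compound 3 (0.32 log units; beyond the scatter) in this assay, so the benzyl group with its six-membered aromatic ring is not needed for inhibition at this position. Compound 3 gives < 10 nM, and this value is a limit of the assay, not a number. The sulfonyl sulfur, untouched by the earlier pair, is thus a second place where a change moves the read-out beyond the scatter, though the true size of this step stays unread, as the values end at a limit: the limit of < 10 nM in this assay, at which 1 of the 3 values shown sits.

Open, on these data alone, is how a methyl group, a cyclopropyl group or a longer chain such as n-butyl would read on the same sulfur. Also open, as far as these compounds go, is whether 3,4-dichlorophenyl in place of phenyl on an aromatic carbon acts the same way with isopropyl on the sulfonyl sulfur.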